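From a Silicon Substituent to a Chloropropyl Chain

This account rests on a few compounds, and the source may have more. Where it says the series, first, only, none or still open, it means among the compounds named here.

Among the compounds with values here, compound 1 `C[Si](C)(C)c1cn(C[C@H](O)[C@H]2OC(=O)C(OCc3ccccc3)=C2OCc2ccccc2)nn1` is the only member of this small set that returns a number in a functional assay on MCF7 cells (Homo sapiens) for antiproliferative activity, read by MTT assay, with a stated time of 72 h; a higher number here means a weaker inhibitor, a lower number a stronger inhibitor: compound 1 gives 12100 nM. Compound 2 `O=C1O/C(=C\Cn2cc(-c3ccc(Br)cc3)nn2)C(OCc2ccccc2)=C1OCc1ccccc1` reaches only the limit of the assay, and in this assay compound 2 gives > 100000 nM. Compound 3 `COc1ccccc1-c1cn(C/C=C2\OC(=O)C(OCc3ccccc3)=C2OCc2ccccc2)nn1` likewise reaches only the limit, and in this assay compound 3 gives > 100000 nM. Within the data shown here, the single measured step, a step that the two limits leave unreadable from compound 2 to compound 3, cannot be read, since both of its ends sit at the limit of > 100000 nM in this assay, at which 2 of the 3 values shown sit. Compounds 2 and 3 differ from compound 1 in more than one place, so their values show only that both lie beyond the range of the assay while compound 1 does not.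

Compound 4 `O=C1O[C@H]([C@@H](O)Cn2cc(CCCCl)nn2)C(OCc2ccccc2)=C1OCc1ccccc1` is not yet measured. It differs from compound 1 in one place: a group of 4 heavy atoms (3 carbon, 1 chlorine; no ring) in place of a group of 4 heavy atoms (3 carbon, 1 silicon; no ring), on an aromatic carbon. Among the measured compounds shown here, no measured step speaks to this change: the only step available sits at a limit and gives no size. With nothing to suggest movement in either direction, compound 4 is expected to stay near compound 1. On that basis compound 4 is estimated at 15000 nM in this assay, with a range from 5000 nM to 50000 nM. That estimate means an expected step of a 1.2-fold higher number from compound 1 to compound 4 (0.09 log units; within the scatter), none beyond the scatter.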

Compound 4, half-maximal inhibitory concentration: 24500 nM
Estimate against measurement, compound 4: 1.6-fold (0.21 log units) below, and the stated range covers the measured number.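

In this assay, within the data shown here, the change on this aromatic carbon of the five-membered aromatic ring with 3 nitrogen is the first step in the set that can be read, and it gives a 2.0-fold higher number from compound 1 to compound 4 (0.31 log units; beyond the scatter). A number in this range does not depend on silicon at this position: compound 4 carries none, with 3-chloropropyl in its place, and it still returns a value, at a modest cost in strength compared with compound 1. Compound 1 and compound 4 are therefore the only pair that gives a readable size for a change, as the rest of the set offers only limits: the limit of > 100000 nM in this assay, at which 2 of the 4 values shown sit.

From the compounds shown here alone, this single step cannot separate the role of the chlorine from that of the chain, so what a plain propyl group, a longer chain ending in chlorine, or an amine or a carboxylic acid at the end of the chain would give at this position remains open. Also open, going by these compounds, is whether the same change would have a step of this size on a core other than that of compound 1.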